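The compounds below may be only part of what the source reports. "The series", "measured", "known", "first", "only" and "open" are said of these compounds alone.

Values measured so far in an ADME assay on microsomes from liver (Rattus norvegicus) for metabolic stability (on this read-out lower numbers stand for slow clearance and higher numbers for fast clearance), are:

compound 1 `CNc1nc(NC(C#N)(C2CC2)C2CC2)nc(-n2cncn2)n1` gives 3.7 mL/min/kg
compound 2 `CNc1nc(NC2(C#N)CCCCC2)nc(-n2ccnc2)n1` gives 52 mL/min/kg
compound 3 `CNc1nc(NC2(C#N)CCCCC2C)nc(-n2cncn2)n1` gives 86 mL/min/kg

Compound 2 stands within the usual scatter of compound 3, while compound 1 lies well below both, a gap clearly beyond that scatter. The next compound to be measured is compound 4 `CNc1nc(NC2(C#N)CCCCC2)nc(-n2cnc(C#N)n2)n1`, which keeps compound 2 unchanged except for one group on an aromatic carbon. There, 3-cyano-1H-1,2,4-triazol-1-yl takes the place of 1H-imidazol-1-yl, and the full count of the change is 3-cyano-1H-1,2,4-triazol-1-yl in place of 1H-imidazol-1-yl on an aromatic carbon in this swap.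

Among the measured compounds shown here, no measured pair shows this swap alone, as compound 1 and compound 3 each differ from compound 2 in more than one place. Compound 1 at 3.7 mL/min/kg shows that low clearance is reachable among these compounds, but compound 3 at 86 mL/min/kg goes against any such lean. A modest fall, only slightly beyond the scatter, is expected, an estimated 2.2-fold lower number from compound 2 to compound 4 (0.34 log units; beyond the scatter) in this series. The estimate for compound 4 is 24 mL/min/kg with an expected range from 8 mL/min/kg to 65 mL/min/kg on present evidence.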

Compound 4, clearance: 210 mL/min/kg
For compound 4 the middle estimate is 8.8-fold (0.94 log units) below the measured one; measured number outside the range, above it.
By their numbers in this assay, from the lowest: compound 1; then compounds 2 and 3 (each within the scatter of the next); then compound 4.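

Among the compounds shown here, this is the first direct reading of the group on the aromatic carbon opposite the ring nitrogen: with the rest of compound 2 held fixed, 3-cyano-1H-1,2,4-triazol-1-yl in place of 1H-imidazol-1-yl gives in this assay a clear change (a 4.0-fold higher number from compound 2 to compound 4 (0.61 log units; beyond the scatter)). Clearance therefore responds to this position, and this particular swap moves it towards faster clearance, by a step beyond the usual scatter. Nothing available explains why the number rises.

Going by these compounds, the swap changes the ring and adds the nitrile in a single step, so the share of each in the rise remains open. Also open, on these data alone, is how a different kind of group at this position, such as a morpholine or a dimethylamino group, would read in this assay on the rest of compound 2.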